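This account rests on a few compounds, and the source may have more. Where it says the series, first, only, none or still open, it means among the compounds named here.

Measured so far:
compound 1 `C=C[C@@](C)(/C=C/c1ccc(OC(=O)CC)cc1)CCC=C(C)C` — 54%
compound 2 `C=C[C@@](C)(/C=C/c1ccc(OC(=O)CCCCC)cc1)CCC=C(C)C` — 28%

In a functional assay on PC-3 cells (Homo sapiens) for inhibition, with a stated time of 48 h, tested at 50 uM (a higher number here means more inhibition of growth at the concentration tested, a lower number less inhibition of growth), compound 1 gives 54%; compound 2 gives 28% in this assay. Among the measured compounds shown here, compound 2 stands lowest of the two numbers; its only neighbour is compound 1, and the step of a number 26 percentage points lower from compound 1 to compound 2 (beyond the scatter) is the sole measured step.

Compound 3 `C=C[C@@](C)(/C=C/c1ccc(OC(=O)CCCCCCCCCCCCCCC)cc1)CCC=C(C)C` is not yet measured. It differs from compound 2 by decyl in place of hydrogen on a saturated chain carbon, five bonds along the chain from a carbonyl carbon. The measured step of a number 26 percentage points lower from compound 1 to compound 2 (beyond the scatter) bears on it, as it is likewise a lengthening of the saturated chain on the carbonyl side, and it ran downward beyond the scatter. For the measured compounds named here, nothing measured shows whether a second, larger lengthening continues in the same direction, levels off, or reverses; only the one step is available. On that basis a further downward step is expected, smaller than the measured one, in the estimated step of a number 13 percentage points lower from compound 2 to compound 3 (beyond the scatter). For compound 3 the estimate in this assay is 15%, with a range from 0% to 40%.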

Compound 3, percent growth inhibition at one concentration: 62%
Compound 3: the middle estimate sits 47 percentage points below what was measured; the whole stated range lies below it.
By their numbers in this assay, from the lowest: compound 2; then compounds 1 and 3 (each within the scatter of the next).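

In this assay the saturated chain on the carbonyl side does not push the number in one direction: a number 34 percentage points higher from compound 2 to compound 3 (beyond the scatter) runs against a number 26 percentage points lower from compound 1 to compound 2 (beyond the scatter) and shows that lengthening at this place can raise the number as well as lower it. Decyl in place of hydrogen, five bonds along the chain from a carbonyl carbon, is therefore tolerated, and a steady fall with chain length is excluded by compound 3, while compound 1 at 54% and compound 3 at 62% lie within the scatter of each other. Nothing available here accounts for this turn in the numbers.

Among the compounds shown here, only three chain lengths are in view, so it remains open where between compound 2 and compound 3 the numbers turn upward, and whether a longer chain would hold the level of compound 3 or lose it. On these data alone, it is equally open whether an amine or a carboxylic acid at the far end of the chain would keep the response seen with compound 3 in this assay or change it.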